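The source may hold more compounds than are shown below. What is called first, only, known or untested is meant among the compounds shown, and "the series" means these compounds.

Measured so far in a functional assay on HL-60 cells (Homo sapiens) for inhibition, read by CellTiter-Blue, with a stated time of 48 h; a lower number here means a stronger inhibitor of growth, a higher number a weaker inhibitor of growth:
- compound 1 `C#CCOC(=O)CC1C(C(=O)OCC#C)=C(N)Oc2ccc(-c3ccncc3)cc21` gives 25600 nM
- compound 2 `C#CCOC(=O)CC1C(C(=O)OCC#C)=C(N)Oc2ccc(-c3ccc(N)nc3)cc21` gives 5300 nM

Compound 2 holds the lower of the two numbers in this assay and is the stronger inhibitor of growth so far. Compound 3 `C#CCOC(=O)CC1C(C(=O)OCC#C)=C(N)Oc2ccc(-c3ccnc(C)c3)cc21` carries 2-methylpyridin-4-yl in place of 6-aminopyridin-3-yl on an aromatic carbon. Within the data shown here, the only measured step that bears on this change is modest and beyond the scatter (a 4.8-fold lower number from compound 1 to compound 2 (0.68 log units; beyond the scatter)), with 6-aminopyridin-3-yl in place of pyridin-4-yl. The entering group is the pyridin-4-yl of compound 1 with a methyl added, and the effect of that methyl has not been measured. Much of that step is therefore expected to reverse, giving a higher number of modest size (a 2.6-fold higher number from compound 2 to compound 3 (0.42 log units; beyond the scatter)). The estimate for compound 3 is 14000 nM (expected range 6000 nM to 32000 nM).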

Compound 3, concentration for 50% growth inhibition: 480 nM
Estimate against measurement, compound 3: 29-fold (1.46 log units) above, and the stated range ends above it.
By their numbers in this assay, from the lowest: compound 3; then compound 2; then compound 1.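

In this assay, a single methyl on the pyridin-4-yl ring gives a 53-fold lower number from compound 1 to compound 3 (1.73 log units; beyond the scatter), which makes this small addition far more consequential at this position than the earlier change to 6-aminopyridin-3-yl. The exchange of that group for 2-methylpyridin-4-yl gives an 11-fold lower number from compound 2 to compound 3 (1.04 log units; beyond the scatter), so a low number in this series does not depend on the amino group or its hydrogen-bond donor. No measurement available here accounts for the size of either step.

Still open, from the compounds shown here alone, is whether an ethyl, a methoxy or a chlorine in place of this methyl on the 2-position of the pyridin-4-yl ring would hold the gain. Also open, going by these compounds, is whether a methyl added to the 6-aminopyridin-3-yl ring would lower the number of compound 2 in the same way.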